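Chain extension at the benzylic amine of compound 2

A few compounds are considered here, and "the series" means these few. Any claim that something is new, unique, unknown or untested is made for them only; others in the source may bear on it.

Among the compounds with values here, compound 2 `CC[C@H](Nc1cncc(-c2ccc(O)c(OC)c2)n1)c1ccccc1` stands level with compound 1 `COc1cc(-c2cncc(N[C@@H](C)c3ccccc3)n2)ccc1O` on the numbers so far: in a functional assay on PC-3 cells (Homo sapiens) for cytotoxicity, read by MTT assay, with a stated time of 72 h (on this read-out lower numbers stand for stronger inhibition and higher numbers for weaker inhibition), compound 1 gives 10000 nM, and compound 2 gives 10000 nM. The step of no change at the digits printed from compound 1 to compound 2 (within the scatter) lies within the scatter. Compound 3 `CCC[C@H](Nc1cncc(-c2ccc(O)c(OC)c2)n1)c1ccccc1` carries the next change, (methyl in place of hydrogen on a saturated chain carbon, three bonds along the chain from an aromatic carbon and a nitrogen on an aromatic ring); the same difference cut one bond further out reads methyl to ethyl, ethyl to propyl. Within the data shown here, the only measured step that bears on it is the flat one already noted, so no movement beyond the scatter is expected, no change at the digits printed from compound 2 to compound 3 (within the scatter). Compound 3 is therefore estimated at 10000 nM, within 5000 nM to 20000 nM.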

Compound 3, half-maximal inhibitory concentration: 160 nM
The estimate for compound 3 lay 63-fold (1.80 log units) above the measured number, and the stated range ends above it.
By their numbers in this assay, from the lowest: compound 3; then compounds 1 and 2 (each within the scatter of the next).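

In this assay, the length of the chain at this saturated carbon matters, but the response is not gradual. Methyl to ethyl is flat (no change at the digits printed from compound 1 to compound 2 (within the scatter)), while ethyl to propyl gives a large drop (a 63-fold lower number from compound 2 to compound 3 (1.80 log units; beyond the scatter)). Taken together, the change from methyl to propyl reads the same (a 63-fold lower number from compound 1 to compound 3 (1.80 log units; beyond the scatter)), so the whole gain appears at the propyl chain.

Going by these compounds, whether butyl, a longer chain or a branched isopropyl group at this carbon would keep the number near that of compound 3 (160 nM) remains open. No measurement shown accounts for the jump.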